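This account rests on a few compounds, and the source may have more. Where it says the series, first, only, none or still open, it means among the compounds named here.

Two compounds of the series carry a number in a physicochemical assay for lipophilicity; on this read-out lower numbers stand for lower lipophilicity and higher numbers for higher lipophilicity. Compound 1 `CNC(=O)c1cc(C(=O)N[C@H]2[C@@H]3C[C@@H](OC)C[C@@H]32)n([C@@H](C)c2ccccc2)n1` gives 2.7, the lowest of the two. Compound 2 `CNC(=O)c1cc(C(=O)N[C@H]2CC[C@H](O)CC2)c([C@@H](C)c2cccc(C)c2)o1` gives 3.3, a number above that of compound 1 and beyond the scatter. Compound 3 `CNC(=O)c1cc(C(=O)N[C@H]2[C@@H]3C[C@@H](O)C[C@@H]32)n([C@@H](C)c2ccccc2)n1` has no number yet in this assay; it differs from compound 1 by hydrogen in place of methyl on an oxygen on a saturated carbon. Going by the values given here, no step between two measured compounds follows this change, so the expectation rests on the change alone. A decrease beyond the scatter is expected, a number 0.80 log units lower from compound 1 to compound 3 (beyond the scatter). For compound 3 the estimate in this assay is 1.9, ranging from 1.4 to 2.4.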

Compound 3, distribution coefficient: 3.2
Beside the measured number, compound 3's estimate is 1.30 log units below it; the measured number lies above the stated range.
By their numbers in this assay, from the lowest: compound 1; then compounds 3 and 2 (each within the scatter of the next).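

In this assay, going by these compounds alone, methoxy to hydroxy on this saturated ring position gives a number 0.50 log units higher from compound 1 to compound 3 (beyond the scatter) and is the first one-place comparison. For this pair, hydrogen in place of methyl on the oxygen raises the read-out, and the modest step shows that the position responds to this small change. No measurement at hand accounts for the direction of this step.

A single pair cannot show whether the direction holds on other cores, including that of compound 2. As far as these compounds go, how an amine, a carboxylic acid or a longer ether chain such as ethoxy would read at this position remains open.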